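Sulfonyl aryl exchange in a quinoline series: compound 2 to 4

This account rests on a few compounds, and the source may have more. Where it says the series, first, only, none or still open, it means among the compounds named here.

Measured compounds:
compound 1, `COCC1CCN(c2c(S(=O)(=O)c3cc(F)cc(F)c3)cnc3cc(F)ccc23)CC1`, 83%
compound 2, `CC1CCN(c2c(S(=O)(=O)c3cc(F)cc(F)c3)cnc3cc(F)ccc23)CC1`, 77%
compound 3, `CC1CCN(c2c(S(=O)(=O)c3ccc(F)cc3)cnc3ccc(Cl)cc23)CC1`, 89%

In an assay on isolated protein for displacement of a labelled ligand from metabotropic glutamate receptor 5 (Homo sapiens), with a stated time of 60 min, tested at 1 uM (on this read-out lower numbers stand for less inhibition and higher numbers for more inhibition at the one concentration tested (going by the name of the read-out)), compound 2 gives the lowest of the three numbers. Its nearest neighbour is compound 1, reached by a number 6 percentage points lower from compound 1 to compound 2 (within the scatter), which is within the scatter. Compound 3 lies further off, beyond the scatter, but compound 3 differs from compound 2 in more than one place, so no single step can be read from that pair. Compound 4, `CC1CCN(c2c(S(=O)(=O)c3ccc(Cl)c(Cl)c3)cnc3cc(F)ccc23)CC1`, is not yet measured; it differs from compound 2 by 3,4-dichlorophenyl in place of 3,5-difluorophenyl on a sulfonyl sulfur. Among the compounds with values here, none of the measured steps touches the group on the sulfonyl sulfur, so there is no basis for a step beyond the scatter in this assay in either direction. Compound 4 is therefore expected to give about 80%, with a range from 65% to 92%. The expected step is a number 3 percentage points higher from compound 2 to compound 4 (within the scatter).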

Compound 4, a percentage reported as inhibition, at one concentration (the size of the read-out at that concentration, not a potency): 94%
Compound 4: middle estimate off by 14 percentage points, on the low side; measured number above the stated range.
By their numbers in this assay, from the lowest: compounds 2, 1, 3 and 4 (each within the scatter of the next, the first and the last beyond it).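

In this assay, the exchange on a sulfonyl sulfur gives a number 17 percentage points higher from compound 2 to compound 4 (beyond the scatter) and so shows that this position can move the number, unlike the earlier step on the saturated chain, which stayed within the scatter. The group that leaves and the group that enters have the same heavy-atom count, and they differ in both halogen and substitution pattern. Nothing shown explains the step.

From the compounds shown here alone, what 3,4-difluorophenyl or 3,5-dichlorophenyl would give on the sulfonyl sulfur stays open, and with it whether the chlorine or its placement carries the step.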